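One side chain swapped on compound 2

The compounds below may be only part of what the source reports. "The series", "measured", "known", "first", "only" and "open" are said of these compounds alone.

Measured so far in a physicochemical assay for solubility, at pH 6.8 (on this read-out lower numbers stand for lower solubility and higher numbers for higher solubility), are two compounds:
compound 1 (`COC(=O)c1nc(-c2ccco2)c(C(F)(F)F)cc1N`) gives 11 ug/mL
compound 2 (`Nc1cc(C(F)(F)F)c(Br)nc1C(=O)NC[C@H](O)C(F)(F)F`) gives 290 ug/mL

Among the measured compounds shown here, compound 2 holds the higher of these two numbers, and compound 1 is its only neighbour. The gap between them lies beyond the usual scatter of repeated measurements. These two compounds differ in more than one place, so the gap cannot be tied to any single structural change.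

The next compound is compound 3 (`CC(C)(O)CNC(=O)c1nc(Br)c(C(F)(F)F)cc1N`). It keeps the core of compound 2 and changes one group on a saturated chain carbon bound to an amide-type nitrogen, where 1-hydroxy-1-methylethyl stands in place of 2,2,2-trifluoro-1-hydroxyethyl (1-hydroxy-1-methylethyl in place of 2,2,2-trifluoro-1-hydroxyethyl on a saturated chain carbon bound to an amide-type nitrogen). For the measured compounds named here, no measured pair shows this swap, so the data offer no direct precedent. The best starting point is compound 2 at 290 ug/mL in this series, and no step beyond the scatter is expected in this assay in either direction. The estimated change is a 1.1-fold higher number from compound 2 to compound 3 (0.04 log units; within the scatter) and this remains an expectation only. For compound 3 the expected value is 320 ug/mL with an estimated range from 100 ug/mL to 1000 ug/mL for now.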

Compound 3, solubility: 28 ug/mL
Estimate against measurement, compound 3: 11-fold (1.06 log units) above; measured number below the stated range.
By their numbers in this assay, from the lowest: compound 1; then compound 3; then compound 2.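

Among the compounds shown here, this is the first change that can be read in one place. In this assay, putting 1-hydroxy-1-methylethyl in place of 2,2,2-trifluoro-1-hydroxyethyl on a saturated chain carbon bound to an amide-type nitrogen goes with a 10-fold lower number from compound 2 to compound 3 (1.02 log units; beyond the scatter). The read-out at this position therefore responds strongly to the end of the side chain, even though both groups have no ring, no net charge and the same count of hydrogen-bond donors and acceptors, and the shared core stays unchanged. No measurement at hand explains the size of this step.

The swap removes the three fluorine atoms and the defined stereocentre together, and it also changes the group from 6 heavy atoms to 4, so the compounds shown cannot separate these differences from one another. Going by these compounds, how this assay would read with an amine or a carboxylic acid at the end of this side chain, or with a longer chain carrying the hydroxyl group, also remains open.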